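Sulfonate ester series: aryl swap on a urea core

This account rests on a few compounds, and the source may have more. Where it says the series, first, only, none or still open, it means among the compounds named here.

Measured so far:
compound 1, `CCC(=O)Nc1ccc(S(=O)(=O)Oc2ccccc2C(C)C)cc1`, 2100 nM
compound 2, `CCC(=O)Nc1ccc(S(=O)(=O)Oc2ccccc2I)cc1`, 7200 nM
compound 3, `CCCCCNC(=O)Nc1ccc(S(=O)(=O)Oc2ccccc2C(C)C)cc1`, 4700 nM

Three members of the series have been run in a functional assay on HT-1080 cells (Homo sapiens) for antiproliferative activity, read by sulforhodamine B assay, with a stated time of 48 h; a higher number here means a weaker inhibitor, a lower number a stronger inhibitor. Compound 1 is the reference point; compound 2 differs from it by iodo in place of isopropyl on an aromatic carbon, and that change gave a 3.4-fold higher number from compound 1 to compound 2 (0.54 log units; beyond the scatter). Compound 3 keeps the aryl portion of compound 1 and alters the core by pentylamino in place of ethyl on a carbonyl carbon; this step gave a 2.2-fold higher number from compound 1 to compound 3 (0.35 log units; beyond the scatter). Compound 3 and compound 2 sit close together in this assay, and their two numbers do not separate.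

The unmeasured compound 4, `CCCCCNC(=O)Nc1ccc(S(=O)(=O)Oc2ccccc2I)cc1`, joins both alterations: it carries the core of compound 3 and differs from compound 3 by iodo in place of isopropyl on an aromatic carbon. The place of this change is described in the same words as for the step from compound 1 to compound 2, so it is the same change made on a different core. Among the measured compounds shown here, only one example of it is known, so the expectation rests on that single step and on the value of compound 3. Compound 4 is expected to follow compound 3 with a 3.0-fold higher number from compound 3 to compound 4 (0.47 log units; beyond the scatter), a step of the same direction and similar size as seen earlier, with some allowance for a different core. Compound 4 is expected at 14000 nM, within 6000 nM to 35000 nM.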

Compound 4, half-maximal inhibitory concentration: 6900 nM
For compound 4 the middle estimate is 2.0-fold (0.31 log units) above the measured one; the range from low to high includes it.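

In this assay, iodo in place of isopropyl on an aromatic carbon, carried to the core of compound 3, gives a 1.5-fold higher number from compound 3 to compound 4 (0.17 log units; within the scatter), and this step cannot be told apart from the one on the core of compound 1: the same change on two cores in this assay, a 3.4-fold higher number (0.54 log units; beyond the scatter) from compound 1 to compound 2 and a 1.5-fold higher number (0.17 log units; within the scatter) from compound 3 to compound 4, 2.3-fold (0.37 log units) apart, within the scatter of two such steps.
Pentylamino in place of ethyl on a carbonyl carbon, read with iodo on the aryl group, gives a 1.0-fold lower number from compound 2 to compound 4 (0.02 log units; within the scatter), and this step likewise cannot be told apart from the one with isopropyl: the same change on two cores in this assay, a 2.2-fold higher number (0.35 log units; beyond the scatter) from compound 1 to compound 3 and a 1.0-fold lower number (0.02 log units; within the scatter) from compound 2 to compound 4, 2.3-fold (0.37 log units) apart, within the scatter of two such steps.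
Among the compounds shown here, the four compounds are therefore compatible with each change carrying from one core to the other, but they do not show that it does so, since each change has only two examples and one step of each pair lies beyond the scatter while the other lies within it.

Going by these compounds, whether the same holds for other groups in place of isopropyl, such as bromo or methoxy, remains open. So does the outcome with an amine or a longer chain in place of pentylamino on the carbonyl carbon.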